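The compounds below may be only part of what the source reports. "The series", "measured", "known", "first", "only" and "open" are said of these compounds alone.

Compound 3 `COC(=O)c1ccc(NCc2cncn2Cc2ccccc2C)cc1-c1ccccc1` is the lowest of the two numbers seen so far in a toxicity assay on NIH3T3 cells (Mus musculus) for cytotoxicity, read by resazurin assay; a lower number here means that less compound is needed, a higher number that more compound is needed for the effect. In this assay compound 3 gives 10000 nM. Among the compounds with values here, its nearest neighbour, compound 2 `COC(=O)c1ccc(NCc2cncn2Cc2ccccc2N)cc1-c1ccccc1`, gives 25000 nM in this assay, and the one measured step, a 2.5-fold lower number from compound 2 to compound 3 (0.40 log units; beyond the scatter), arises from methyl in place of amino on an aromatic carbon. Compound 1 `COC(=O)c1ccc(NCc2cncn2Cc2ccccc2C(C)(C)C)cc1-c1ccccc1` has no result in this assay: for compound 1 the entry reads "not determined" (no result reported).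

Compound 4 `COC(=O)c1ccc(NCc2cncn2Cc2cccc(C(C)(C)C)c2)cc1-c1ccccc1` carries 3-(tert-butyl)phenyl in place of 2-methylphenyl on a saturated chain carbon bound to an aromatic nitrogen. Within the data shown here, no measured step involves a change of this kind; the only step on record, a 2.5-fold lower number from compound 2 to compound 3 (0.40 log units; beyond the scatter), concerns a different group and does not bear directly on the exchange of 2-methylphenyl for 3-(tert-butyl)phenyl. With nothing comparable to lean on, the expectation for compound 4 is a step of about a 1.3-fold lower number from compound 3 to compound 4 (0.10 log units; within the scatter), which stays within the scatter of the method, with no clear direction. Compound 4 is therefore estimated at 8000 nM in this assay, with a range from 3000 nM to 25000 nM.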

Compound 4, half-maximal effective concentration: > 1000 nM
Compound 4 ended at the assay's limit (the forecaster's own chance of this, stated with the estimate: 10%); the middle value lies beyond the limit too.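

In this assay compound 4 gives > 1000 nM, which is a limit of the assay and not a number. Its steps from compound 2 and compound 3 therefore cannot be read: the limit of > 1000 nM in this assay, at which 1 of the 4 values shown sits.

The compounds shown leave open whether 3-(tert-butyl)phenyl in place of 2-methylphenyl changes the number at all.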